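A few compounds are considered here, and "the series" means these few. Any claim that something is new, unique, unknown or untested is made for them only; others in the source may bear on it.

Measured so far, in a functional assay on HCT-15 cells (Homo sapiens) for inhibition; a lower number here means a stronger inhibitor, a higher number a weaker inhibitor:
compound 1 `Oc1ccc(-c2cc(-c3cccc(C(F)(F)F)c3)cc(-c3ccc(O)cc3)n2)cc1` gives only a limit, > 50000 nM.
compound 2 `Oc1ccccc1-c1cc(-c2cccc(OC(F)(F)F)c2)cc(-c2ccccc2O)n1` gives only a limit, > 50000 nM.
compound 3 `Oc1ccc(-c2cc(-c3cccc(OC(F)(F)F)c3)cc(-c3ccccc3O)n2)cc1` gives only a limit, > 50000 nM.

Compound 3 therefore stands at the same limit as the two other measured compounds; no number for it is known, and all three values coincide, as recorded in the limit of > 50000 nM in this assay, at which 3 of the 3 values shown sit. Among the compounds with values here, the only measured single-site change, a step that the two limits leave unreadable from compound 2 to compound 3, concerns the same exchange of hydroxyphenyl groups and cannot be sized, since both of its ends are limits.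

Compound 4 `Oc1ccc(-c2cc(-c3cccc(OC(F)(F)F)c3)cc(-c3ccc(O)cc3)n2)cc1` differs from compound 3 by 4-hydroxyphenyl in place of 2-hydroxyphenyl on an aromatic carbon. Within the data shown here, the one measured step that bears on this change is unreadable, so it yields neither a size nor a direction; the bare record is that compound 1, compound 2 and compound 3 all sit at the limit (the limit of > 50000 nM in this assay, at which 3 of the 3 values shown sit). Because of the limit of > 50000 nM in this assay, at which 3 of the 3 values shown sit, compound 4 is expected to stay at the limit in this assay as well, with a step that the limit leaves unreadable from compound 3 to compound 4 expected to be none beyond the scatter. The estimate for compound 4 is 60000 nM, with a range from 30000 nM to 200000 nM.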

Compound 4, half-maximal inhibitory concentration: > 50000 nM
Compound 4: a limit, no number (the forecaster's own chance of this, stated with the estimate: 85%); the middle value lies beyond the limit too.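

In this assay, the steps from compound 3 and from compound 1 to compound 4 cannot be read, as both ends of each are limits. The compounds shown leave open whether either exchange changes inhibition at all, and all share one bound: the limit of > 50000 nM in this assay, at which 4 of the 4 values shown sit.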